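Swapping a Thiophene for Methoxyphenyl: Expected Tolerability

The compounds below may be only part of what the source reports. "The series", "measured", "known", "first", "only" and "open" are said of these compounds alone.

Measured so far:
compound 1, `Cc1cc(-c2cccs2)cn2c(CSCCc3ccccc3)cnc12`, 32 ug/mL
compound 2, `Cc1cc(-c2ccsc2)c2ncc(CSCCc3ccccc3)n2c1`, > 50 ug/mL

Of the compounds shown here, two sharing one core have been tested in an ADME assay on HEL cells (Homo sapiens) for cytotoxicity, with a stated time of 3 days; a higher number here means that more compound is tolerated, a lower number that less compound is tolerated. Compound 1, `Cc1cc(-c2cccs2)cn2c(CSCCc3ccccc3)cnc12`, gives 32 ug/mL, a plain number. Compound 2, `Cc1cc(-c2ccsc2)c2ncc(CSCCc3ccccc3)n2c1`, is reported only as > 50 ug/mL, which is a limit of the assay rather than a number; this is the limit of > 50 ug/mL in this assay, at which 1 of the 2 values shown sits. So compound 2 stands at the edge of what this assay can report, and the gap between the two measured compounds cannot be sized.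

Compound 3, `COc1ccc(-c2cc(C)cn3c(CSCCc4ccccc4)cnc23)cc1`, is not yet measured. Its change from compound 2 is 4-methoxyphenyl in place of thiophen-3-yl on an aromatic carbon.

Going by the values given here, no measured step exists for this kind of change, so the expectation rests on the two values alone, which sit close to each other. Compound 3 is therefore expected to tolerate a similar amount of compound, with a step in this assay of an at least 1.1-fold lower number from compound 2 to compound 3 (0.04 log units; that floor lies within the scatter), not beyond the scatter. The estimate for compound 3 in this assay is 45 ug/mL, within a range from 20 ug/mL to 100 ug/mL.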

Compound 3, half-maximal cytotoxic concentration: 19.6 ug/mL
For compound 3 the middle estimate is 2.3-fold (0.36 log units) above the measured one; the whole stated range lies above it.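

In this assay, 4-methoxyphenyl in place of thiophen-3-yl on this aromatic carbon gives an at least 2.5-fold lower number from compound 2 to compound 3 (0.40 log units; beyond the scatter) and so shows that the group held at this position, ortho to a fused ring, can change how much compound the cells tolerate. Going by these compounds alone, this is the first step measured at this position, and it lies beyond the usual scatter even though the entering and leaving groups are both uncharged aromatic rings with the same counts of hydrogen-bond donors and acceptors. The value of compound 2 is a limit and not a number, so the step gives only a floor on the size of the change: the limit of > 50 ug/mL in this assay, at which 1 of the 3 values shown sits.

Within the data shown here, the single step combines two changes, a new ring and an added methoxy group, so it remains open which of them accounts for the lower number, and a plain phenyl group on this carbon would help to separate the two. Going by these compounds, it also remains open whether an amine or a carboxylic acid on the same ring would shift the tolerated amount in the same direction.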